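The source may report more compounds than this note shows. Statements on the series, on what has been measured and on what is new or still open speak of the compounds shown alone.

Measured so far in a functional assay on HL-60 cells (Homo sapiens) for cytotoxicity, read by MTT assay, with a stated time of 48 h; on this read-out lower numbers stand for stronger inhibition and higher numbers for weaker inhibition:
compound 1 `Fc1cccc(-c2nc(Nc3ccccc3)c3cc(F)ccc3n2)c1`, 48300 nM
compound 2 `Oc1ccccc1Nc1nc(-c2cccc(F)c2)nc2ccc(F)cc12`, 44400 nM

Compound 2 sits alongside compound 1 inside the scatter of this assay: a 1.1-fold lower number from compound 1 to compound 2 (0.04 log units; within the scatter), a hydroxy in place of hydrogen on an aromatic carbon. Compound 3 `Nc1cccc(Nc2nc(-c3cccc(F)c3)nc3ccc(F)cc23)c1` differs from compound 2 by 3-aminophenyl in place of 2-hydroxyphenyl on a nitrogen on an aromatic ring. Among the measured compounds shown here, no measured step covers this exchange; the only one recorded, from hydrogen to hydroxy, left this assay unchanged beyond the scatter, and the exchanged ring is small in both cases. For compound 3 the expected step is a 1.0-fold higher number from compound 2 to compound 3 (0.01 log units; within the scatter), none beyond the scatter. Compound 3 is therefore estimated at 45000 nM, between 20000 nM and 100000 nM.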

Compound 3, half-maximal inhibitory concentration: > 50000 nM
Compound 3: only a limit was reported (the forecaster's own chance of this, stated with the estimate: 10%); middle value at least 1.1-fold (0.04 log units) from the limit.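

Compound 3 gives a limit and not a number in this assay: the limit of > 50000 nM in this assay, at which 1 of the 3 values shown sits. Amino on this ring, in the form of 3-aminophenyl, gives an at least 1.1-fold higher number from compound 2 to compound 3 (0.05 log units; that floor lies within the scatter), and read as amino in place of hydrogen on an aromatic carbon it gives an at least 1.0-fold higher number from compound 1 to compound 3 (0.01 log units; that floor lies within the scatter). Moving from hydroxy to amino on this ring therefore brings no fall in the number, and both floors stay within the scatter.

From the compounds shown here alone, how far compound 3 lies past its limit stays open. Going by these compounds, whether a carboxylic acid or a dimethylamino group on this ring would bring the number down also stays open.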